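Chain methyl on compound 2: cytotoxicity outlook

This account rests on a few compounds, and the source may have more. Where it says the series, first, only, none or still open, it means among the compounds named here.

Measured in an ADME assay on RAW264.7 cells (Mus musculus) for cytotoxicity, read by neutral red uptake, with a stated time of 24 h; on this read-out higher numbers stand for lower toxicity in this test and lower numbers for higher toxicity in this test:
- compound 1 `C=CCONC(=O)C(C)N1C(=O)S/C(=C\c2ccc(C(F)(F)F)cc2)C1=O`: > 128000 nM, a limit
- compound 2 `C=CCONC(=O)CN1C(=O)S/C(=C\c2ccc(F)cc2)C1=O`: > 128000 nM, a limit

Compound 2 gives only a limit, > 128000 nM, and no number. Both measured compounds sit at the same limit: the limit of > 128000 nM in this assay, at which 2 of the 2 values shown sit.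

Compound 3 `C=CCONC(=O)C(C)N1C(=O)S/C(=C\c2ccc(F)cc2)C1=O` differs from compound 2 in one place, methyl in place of hydrogen on a saturated chain carbon bound to an amide-type nitrogen in a ring and a carbonyl carbon. For the measured compounds named here, no measured step isolates this change. Compound 1 also carries this methyl, and compound 1 gives a limit, > 128000 nM. In this assay, the expected step of a number no higher from compound 2 to compound 3 (the limit leaves the size open) is none beyond the scatter. The estimated value for compound 3 is 128000 nM, with an expected range from 70000 nM to 256000 nM.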

Compound 3, half-maximal cytotoxic concentration: > 128000 nM
Compound 3 gave a limit, no number; the forecaster's own chance of this, stated with the estimate: 85%; the middle value sits exactly at the limit.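

No step can be read in this assay between compound 2 and compound 3 or between compound 1 and compound 3, as all three values are limits and not numbers: the limit of > 128000 nM in this assay, at which 3 of the 3 values shown sit.

The compounds shown leave open the actual half-maximal cytotoxic concentration of each compound, and so whether the chain methyl or fluoro in place of trifluoromethyl changes it at all.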